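A few compounds are considered here, and "the series" means these few. Any claim that something is new, unique, unknown or untested is made for them only; others in the source may bear on it.

Working notes on the series. Among the measured compounds shown here, in a functional assay on K562 cells (Homo sapiens) for antiproliferative activity, read by MTT assay, with a stated time of 48 h (on this read-out lower numbers stand for stronger inhibition and higher numbers for weaker inhibition), compound 2 (`COc1ccc(CN2C(=O)C(=O)c3cc(-c4cccc(OC)c4)ccc32)cc1`) gives 100 nM, the lower of the two numbers so far. Compound 1 (`COc1ccc(-c2ccc3c(c2)C(=O)C(=O)N3Cc2ccc(F)cc2)cc1`) gives 560 nM, and this gap lies beyond the scatter. The next entry is compound 3 (`COc1ccc(CN2C(=O)C(=O)c3cc(-c4ccc(Cl)cc4)ccc32)cc1`), which carries 4-chlorophenyl in place of 3-methoxyphenyl on an aromatic carbon of the shared core: 4-chlorophenyl in place of 3-methoxyphenyl on an aromatic carbon.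

For the measured compounds named here, no measured pair isolates this change, so there is no direct precedent for its size or direction in this assay. Going by the values given here, the only guide is the span of the two values. Compound 2 at 100 nM marks the low end of that span, and compound 1 at 560 nM marks the high end. Among the compounds with values here, with only two values at hand, a new substituent is more likely to land inside this span than below it. The expected change is a 2.2-fold higher number from compound 2 to compound 3 (0.34 log units; beyond the scatter), a modest move towards weaker inhibition that may only just clear the scatter. For compound 3 the estimate is 220 nM, with an expected range of 70 nM to 700 nM.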

Compound 3, half-maximal inhibitory concentration: 230 nM
Beside the measured number, compound 3's estimate is 1.0-fold (0.02 log units) below it, and the stated range covers the measured number.
By their numbers in this assay, from the lowest: compound 2; then compound 3; then compound 1.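

In this assay the series now has its first pair differing in one place, and it gives a 2.3-fold higher number from compound 2 to compound 3 (0.36 log units; beyond the scatter), so this aromatic carbon of the shared core responds to the choice of aryl group, though only modestly. The swap removes the methoxy oxygen, the one hydrogen-bond acceptor in the leaving group, and brings in chlorine, yet compound 3 stays at 230 nM, so activity at this position does not depend on keeping 3-methoxyphenyl. Nothing available on these compounds accounts for the size or direction of this step.

The single pair changes both the atom on the phenyl ring and where that ring carries it, so the compounds shown leave open whether the step follows from chlorine replacing methoxy or from the different substitution pattern. Also open, as far as these compounds go, is how this position responds to groups of another kind, such as an amine or a carboxylic acid on the phenyl ring, or a longer chain in place of the ring.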